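The source may report more compounds than this note shows. Statements on the series, on what has been measured and on what is new or still open speak of the compounds shown alone.

Compound 1 `CC(C(=O)N1CCN(c2ccccc2)CC1)N1C(=O)CCC1=O` is the starting point. In a functional assay on the whole organism (strain Swiss) with Mus musculus as the target, in the maximal electroshock model, with a stated time of 0.25 h, at a dose of 300 mg/kg by the intraperitoneal route (a lower number here means a weaker effect, a higher number a stronger effect of the compound at the dose given), compound 1 gives 100%, level with compound 3 `CC(C(=O)N1CCN(c2ccccc2C(F)(F)F)CC1)N1C(=O)CCC1=O`, which gives 100%; together these are the highest of the three numbers. Compound 2 `CCC(C(=O)N1CCN(c2ccccc2Cl)CC1)N1C(=O)CCC1=O` gives 50%, a clearly lower number, beyond the scatter, but it differs from compound 1 in more than one place, so no single step can be read from it.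

Compound 4 `CC(C(=O)N1CCN(c2cccc(F)c2)CC1)N1C(=O)CCC1=O` differs from compound 1 by fluoro in place of hydrogen on an aromatic carbon. Going by the values given here, the one measured step that bears on this, no change at the digits printed from compound 1 to compound 3 (within the scatter), placed a group on the same ring and left the number unchanged. Compound 4 is therefore expected to show no change at the digits printed from compound 1 to compound 4 (within the scatter), and its activity is estimated at 100%, between 75% and 100%.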

Compound 4, a percentage reported as activity, at one dose (the size of the read-out at that dose, not a potency): 100%
The estimate for compound 4 equals the measured number at the digits printed; measured number inside the range.
By their numbers in this assay, from the lowest: compound 2; then compounds 1, 3 and 4 (each within the scatter of the next).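

In this assay a single fluoro meta to a large group on the aromatic ring leaves the read-out in place, with no change at the digits printed from compound 1 to compound 4 (within the scatter) and so this position accepts that small change, which the trifluoromethyl step did not show. Nothing measured here offers an explanation for this result. The compounds shown leave open whether a larger or charged group at this same place, such as an amine or a carboxylic acid, would keep the effect. They also leave open how a methoxy group or a longer chain would behave there.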